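Sulfonyl side chain variation and liver microsomal stability

The compounds below may be only part of what the source reports. "The series", "measured", "known", "first", "only" and "open" are said of these compounds alone.

Measured compounds in an ADME assay on microsomes from liver (Homo sapiens) for metabolic stability, with a stated time of 10 min; a lower number here means that less of the compound is left, a higher number that more of the compound is left:
Compound 1 `CC(C)S(=O)(=O)NC(=O)c1ccc(Nc2nc(NC3(c4ccc(Cl)cc4)CC3)nc(OCC(F)(F)F)n2)cc1` gives 100%.
Compound 2 `CCS(=O)(=O)NC(=O)c1ccc(Nc2nc(NC3(c4ccc(Cl)cc4)CC3)nc(OCC(F)(F)F)n2)cc1` gives 100%.
Compound 3 `CC(C)(C)CNCCS(=O)(=O)NC(=O)c1ccc(Nc2nc(NC3(c4ccc(Cl)cc4)CC3)nc(OCC(F)(F)F)n2)cc1` gives 89%.

Compound 3 stands lowest of the three in this assay; its nearest neighbour is compound 1 and its furthest is compound 2, both of which lie higher than compound 3 by a margin beyond the scatter. Compound 1 and compound 2 are indistinguishable from each other, as no change at the digits printed from compound 1 to compound 2 (within the scatter) shows.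

Compound 4 `CC(C)NC(=O)NCCS(=O)(=O)NC(=O)c1ccc(Nc2nc(NC3(c4ccc(Cl)cc4)CC3)nc(OCC(F)(F)F)n2)cc1` differs from compound 3 by isopropylcarbamoyl in place of neopentyl on an amine nitrogen. Within the data shown here, no measured step covers this change directly. The steps that come closest are a number 11 percentage points lower from compound 1 to compound 3 (beyond the scatter) and a number 11 percentage points lower from compound 2 to compound 3 (beyond the scatter), both modest downward moves that arrived with the neopentylamino chain. Compound 4 takes the neopentyl away again and puts an isopropylcarbamoyl in its place, so a small recovery toward the level of compound 1 and compound 2 is expected, though it may stay within the scatter. For compound 4 this change is expected to mean a number 5 percentage points higher from compound 3 to compound 4 (within the scatter). For compound 4 the estimate in this assay is 94%, with a range from 82% to 100%.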

Compound 4, percent of the compound remaining: 100%
Compound 4: middle estimate off by 6 percentage points, on the low side, within the range that was stated.
By their numbers in this assay, from the lowest: compound 3; then compounds 1, 2 and 4 (each within the scatter of the next).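

In this assay, the drop seen with compound 3 does not extend to every substituted 2-aminoethyl chain on the sulfonyl sulfur: isopropylcarbamoyl in place of neopentyl on the amine nitrogen gives a number 11 percentage points higher from compound 3 to compound 4 (beyond the scatter), a modest step beyond the scatter. The 2-((isopropylcarbamoyl)amino)ethyl chain keeps the level of the small chains, with no change at the digits printed from compound 2 to compound 4 (within the scatter) and no change at the digits printed from compound 1 to compound 4 (within the scatter), so among these four compounds only the neopentylamino chain of compound 3 stands apart. Nothing available here bears on the reason for this difference.

Open, from the compounds shown here alone, is whether the neopentyl group itself or the uncarbamoylated amine nitrogen sets the level of compound 3, a point that a small alkyl group or an unsubstituted primary amine at that nitrogen would address. Also open, going by these compounds, is how a carboxylic acid at the chain end or a longer chain would read here.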